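This account rests on a few compounds, and the source may have more. Where it says the series, first, only, none or still open, it means among the compounds named here.

For the measured compounds named here, compound 2 `Cc1ccc(C(CCn2ccnc2)Oc2ccc(Cl)cc2Cl)cc1` gives 31400 nM in a functional assay on K562 cells (Homo sapiens) for cytotoxicity (a higher number here means that more compound is tolerated, a lower number that less compound is tolerated), the lowest of the three numbers so far. Compound 1 `Clc1ccc(OC(CCn2ccnc2)c2ccccc2)c(Cl)c1` gives 96700 nM in this assay, and compound 3 `O=[N+]([O-])c1ccc(OC(CCn2ccnc2)c2ccccc2)cc1` gives 102000 nM in this assay; compound 2 lies beyond the scatter below both, while the values of compound 1 and compound 3 sit within the scatter of each other. Going by the values given here, the only step at the same ring position is a 3.1-fold lower number from compound 1 to compound 2 (0.49 log units; beyond the scatter), a modest lowering. Compound 4 `Clc1ccc(C(CCn2ccnc2)Oc2ccc(Cl)cc2Cl)cc1` differs from compound 2 by chloro in place of methyl on an aromatic carbon, on an aromatic carbon of a six-membered aromatic ring of carbon only, para to a large group. Among the compounds with values here, no measured step exchanges one substituent for another at this carbon; the series holds only the entry of methyl there. Both the group that leaves and the group that enters count one heavy atom, so a step no larger than the scatter, or at most a small lowering, is expected, and the step from compound 2 to compound 4 is estimated as a 1.3-fold lower number from compound 2 to compound 4 (0.12 log units; within the scatter). Compound 4 is expected to give 24000 nM in this assay, within 10000 nM to 65000 nM.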

Compound 4, half-maximal cytotoxic concentration: 54000 nM
Compound 4: middle estimate off by 2.3-fold (0.35 log units), on the low side; low and high end bracket the measured number.
By their numbers in this assay, from the lowest: compounds 2, 4, 1 and 3 (each within the scatter of the next, the first and the last beyond it).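

In this assay, chloro in place of methyl on this aromatic carbon, para to a large group, gives a 1.7-fold higher number from compound 2 to compound 4 (0.24 log units; within the scatter) and so does not separate the two groups. Chloro in place of hydrogen at the same carbon gives a 1.8-fold lower number from compound 1 to compound 4 (0.25 log units; within the scatter) as its step, while methyl in place of hydrogen gave a 3.1-fold lower number from compound 1 to compound 2 (0.49 log units; beyond the scatter) and remains the only entry at this carbon that lies beyond the scatter. No measurement on these compounds offers an explanation for these steps.

Open, as far as these compounds go, is whether another group at this carbon, such as an amine, a carboxylic acid or a longer chain, moves the number further from that of compound 1. Also open, from the compounds shown here alone, is whether methyl and chloro at this carbon behave alike on the core of compound 3.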